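This account rests on a few compounds, and the source may have more. Where it says the series, first, only, none or still open, it means among the compounds named here.

Compound 1 `Cc1cc(/C=C/C#N)cc(C)c1Oc1cc(NCCN2CCN(C)CC2)nc(Nc2ccc(C#N)cc2)c1` gives 7960 nM in an ADME assay on MT4 cells (Homo sapiens) for cytotoxicity, read by MTT assay, with a stated time of 5 days (on this read-out lower numbers stand for higher toxicity in this test and higher numbers for lower toxicity in this test), and stands highest of the three numbers measured there; compound 2 `Cc1cc(/C=C/C#N)cc(C)c1Oc1cc(NC2CC2)nc(Nc2ccc(C#N)cc2)n1` gives 3000 nM, and compound 3 `Cc1cc(/C=C/C#N)cc(C)c1Oc1cc(NCCC#N)nc(Nc2ccc(C#N)cc2)n1` gives 1000 nM. Among the compounds with values here, the only step measured is a 3.0-fold lower number from compound 2 to compound 3 (0.48 log units; beyond the scatter), a change on a nitrogen on an aromatic ring that does not touch the part of the molecule altered here, so it bears only loosely on the present step. Compound 4 `Cc1cc(/C=C/C#N)cc(C)c1Oc1cc(NCC2CCCO2)nc(Nc2ccc(C#N)cc2)c1` differs from compound 1 in one place: oxolan-2-yl in place of (4-methylpiperazin-1-yl)methyl on a saturated chain carbon bound to a nitrogen on an aromatic ring. Within the data shown here, no measured pair in this set shares this change, so the expectation rests on the standing of compound 1 and on the spread of the three numbers, which all fall within a fairly narrow band. The number for compound 4 is therefore expected to stay near that of compound 1, with a shift of a 1.6-fold lower number from compound 1 to compound 4 (0.20 log units; within the scatter) toward somewhat lower values in this assay considered plausible but not firmly indicated. For compound 4 the estimate in this assay is 5000 nM, within a range of 1500 nM to 15000 nM.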

Compound 4, half-maximal cytotoxic concentration: 73600 nM
Compound 4: middle estimate off by 15-fold (1.17 log units), on the low side; measured number outside the range, above it.
By their numbers in this assay, from the lowest: compound 3; then compound 2; then compound 1; then compound 4.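

In this assay the side chain on this nitrogen moves the number upward, with a 9.2-fold higher number from compound 1 to compound 4 (0.97 log units; beyond the scatter) when oxolan-2-yl replaces (4-methylpiperazin-1-yl)methyl. The earlier compounds shown here offered only a downward step on a nitrogen on an aromatic ring, a 3.0-fold lower number from compound 2 to compound 3 (0.48 log units; beyond the scatter) on replacing cyclopropyl with 2-cyanoethyl, so substituents at such a nitrogen are now seen to shift the number in either direction, though the two steps sit on compounds of different cores. No measurement at hand accounts for the size of the new step.

As far as these compounds go, whether the rise follows the departure of the 2-(4-methylpiperazin-1-yl)ethyl group or the arrival of the (oxolan-2-yl)methyl group remains open. A 2-(morpholin-4-yl)ethyl group on the same nitrogen of the core of compound 1 would help separate the two.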